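Compound 4 and an untested group on the saturated ring

This account rests on a few compounds, and the source may have more. Where it says the series, first, only, none or still open, it means among the compounds named here.

Measured so far:
Compound 1 `CC1CCN(CC[C@H]2CCCN2S(=O)(=O)c2ccc3cc[nH]c3c2)CC1` gives 2.4 nM in an assay on HEK293 cells for binding affinity to 5-hydroxytryptamine receptor 7 (Homo sapiens), read by radioligand binding; on this read-out higher numbers stand for weaker inhibition and lower numbers for stronger inhibition.
Compound 2 `O=S(=O)(c1ccc2cc[nH]c2c1)N1CCC[C@@H]1CCN1CCC(c2c[nH]c3ccccc23)CC1` gives 0.676 nM in this assay.
Compound 3 `O=S(=O)(c1ccc2cc[nH]c2c1)N1CCC[C@@H]1CCN1CCC(c2cc3ccccc3[nH]2)CC1` gives 6.31 nM in this assay.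

Compound 3 stands highest of the three numbers in this assay, as the steps of a 2.6-fold higher number from compound 1 to compound 3 (0.42 log units; beyond the scatter) and a 9.3-fold higher number from compound 2 to compound 3 (0.97 log units; beyond the scatter) show. Compound 4 `O=c1oc2ccccc2n1C1CCN(CC[C@H]2CCCN2S(=O)(=O)c2ccc3cc[nH]c3c2)CC1` differs from compound 3 by a group of 10 heavy atoms (7 carbon, 1 nitrogen, 2 oxygen; one five-membered aromatic ring with 2 hetero atoms, one six-membered aromatic ring of carbon only) in place of a group of 9 heavy atoms (8 carbon, 1 nitrogen; one five-membered aromatic ring with 1 hetero atom, one six-membered aromatic ring of carbon only), on a saturated ring carbon. All three measured steps change the group at this same saturated ring carbon: a 3.6-fold lower number from compound 1 to compound 2 (0.55 log units; beyond the scatter), a 2.6-fold higher number from compound 1 to compound 3 (0.42 log units; beyond the scatter) and a 9.3-fold higher number from compound 2 to compound 3 (0.97 log units; beyond the scatter). None of them introduces the entering group, so they fix only the spread such changes have produced in this assay. A modest step toward a lower number is expected. Compound 4 is therefore estimated at 2 nM, with a range from 0.5 nM to 8 nM, which is the expected step of a 3.2-fold lower number from compound 3 to compound 4 (0.50 log units; beyond the scatter).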

Compound 4, inhibition constant: 1.82 nM
Estimate against measurement, compound 4: 1.1-fold (0.04 log units) above; the measured number falls inside the stated range.
By their numbers in this assay, from the lowest: compound 2; then compounds 4 and 1 (each within the scatter of the next); then compound 3.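

In this assay, the saturated ring carbon also accepts a group with two hetero atoms in its five-membered aromatic ring, and this group differs clearly from both indolyl groups: a 3.5-fold lower number from compound 3 to compound 4 (0.54 log units; beyond the scatter) and a 2.7-fold higher number from compound 2 to compound 4 (0.43 log units; beyond the scatter). Against the methyl group it gives only a 1.3-fold lower number from compound 1 to compound 4 (0.12 log units; within the scatter), so a group of 10 heavy atoms here need not shift the number from that of one carbon atom. Nothing among the available data accounts for these steps.
From the compounds shown here alone, whether a phenyl group or a simple amine on this carbon would reach the low number of compound 2 stays open, as does whether the new group behaves alike on a different core.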